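The compounds below may be only part of what the source reports. "The series", "measured", "known", "first", "only" and "open" are said of these compounds alone.

Compound 1, `C#CCO/N=C/c1c(-c2ccc(C)cc2)nc2ccc(Br)cn12`, opens the series. In a functional assay on the whole organism (strain NMRI) with Mus musculus as the target, with a stated time of 4 h (a higher number here means that more compound is needed for the effect, a lower number that less compound is needed), compound 1 gives 40 mg/kg. Compound 2, `Cc1ccc(-c2nc3ccc(Br)cn3c2/C=N/O)cc1`, keeps the core of compound 1 and differs from it in one place only: hydrogen in place of propargyl on an oxygen. In this assay compound 2 gives 20 mg/kg. The step of a 2.0-fold lower number from compound 1 to compound 2 (0.30 log units; within the scatter) is small, and the two values cannot be ordered with confidence.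

Compound 3, `C#CCO/N=C/c1c(-c2ccc(F)cc2)nc2c(C)cccn12`, is built on a different core; the difference between the two cores is not broken down here. In this assay compound 3 gives 100 mg/kg, the highest number of the three measured, and its distance to compound 1 and to compound 2 lies beyond the scatter.

Compound 4, `Cc1cccn2c(/C=N/O)c(-c3ccc(F)cc3)nc12`, has not yet been measured. It stands to compound 3 exactly as compound 2 stands to compound 1: hydrogen in place of propargyl on an oxygen. The place is described in the same words in both cases, an oxygen whose other neighbour is a double-bonded nitrogen, so this is the same change made a second time, now on the core of compound 3.

The expectation for compound 4 in this assay is a step of a 2.0-fold lower number from compound 3 to compound 4 (0.30 log units; within the scatter). For the measured compounds named here, that expectation rests on the earlier step of a 2.0-fold lower number from compound 1 to compound 2 (0.30 log units; within the scatter), the only precedent for this change, and on the assumption that the change behaves alike on the two cores. Compound 4 is therefore estimated at 50 mg/kg, with a range from 25 mg/kg to 100 mg/kg.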

Compound 4, minimum effective dose: 40 mg/kg
Compound 4: the middle estimate sits 1.3-fold (0.10 log units) above what was measured, and the stated range covers the measured number.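

In this assay, putting hydrogen in place of propargyl on the oxygen gives a 2.5-fold lower number from compound 3 to compound 4 (0.40 log units; beyond the scatter), and this step stands close in size to the one seen for the same change on the other core: the same change on two cores in this assay, a 2.0-fold lower number (0.30 log units; within the scatter) from compound 1 to compound 2 and a 2.5-fold lower number (0.40 log units; beyond the scatter) from compound 3 to compound 4, 1.3-fold (0.10 log units) apart, within the scatter of two such steps. On these two cores, then, the change carries over with a size that cannot be told apart, and a step read from one core served as a fair guide to the step on the other. For the compounds shown here, this does not show that the change would behave alike on any further core: it rests on only two pairs, the earlier step alone lies within the scatter, and the two steps say nothing about why the change has the size it has.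

The compounds shown carry only propargyl or hydrogen on that oxygen, so it remains open what a methyl group, a longer chain or a carboxylic acid in the same place would do, and whether such a group would travel between the cores as closely. The difference between the core of compound 1 and the core of compound 3 also remains unresolved, since no pair shown separates its parts.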